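Trimethoxyphenyl in place of styryl on the pyrazoline carbon

This account rests on a few compounds, and the source may have more. Where it says the series, first, only, none or still open, it means among the compounds named here.

Two pyrazoline sulfonamides bearing a 5-chloro-2-hydroxy-4-methylphenyl group have been measured in a functional assay on U-251 cells (Homo sapiens) for antiproliferative activity, with a stated time of 48 h; a higher number here means a weaker inhibitor of growth, a lower number a stronger inhibitor of growth. Compound 1 `Cc1cc(O)c(C2=NN(c3ccc(S(N)(=O)=O)cc3)C(c3ccccc3O)C2)cc1Cl` gives 7760 nM. Compound 2 `Cc1cc(O)c(C2=NN(c3ccc(S(N)(=O)=O)cc3)C(/C=C/c3ccccc3)C2)cc1Cl` gives 15600 nM. Within the data shown here, the one measured step, a 2.0-fold higher number from compound 1 to compound 2 (0.30 log units; within the scatter), exchanges 2-hydroxyphenyl for 2-phenylethenyl on a saturated ring carbon, and it stays within the scatter, so the two compounds cannot be told apart on these numbers.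

Compound 3 `COc1ccc(C2CC(c3cc(Cl)c(C)cc3O)=NN2c2ccc(S(N)(=O)=O)cc2)c(OC)c1OC` has not yet been measured in this assay. It differs from compound 2 in one place: 2,3,4-trimethoxyphenyl in place of 2-phenylethenyl on a saturated ring carbon. Among the measured compounds shown here, the only step that bears on this change is the one from an aryl group to a styryl group at the same ring carbon, which moved the number by an amount inside the scatter. Returning to an aryl group, now carrying three methoxy groups, is therefore expected to give no step beyond the scatter, perhaps a slight drift toward the number of compound 1. The expected step is a 1.6-fold lower number from compound 2 to compound 3 (0.19 log units; within the scatter). Compound 3 is therefore estimated at 10000 nM, with a range from 3500 nM to 28000 nM.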

Compound 3, concentration for total growth inhibition: 8890 nM
The estimate for compound 3 lay 1.1-fold (0.05 log units) above the measured number; low and high end bracket the measured number.
By their numbers in this assay, from the lowest: compounds 1, 3 and 2 (each within the scatter of the next).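

In this assay, the second comparison at this saturated ring carbon again stays within the scatter: the exchange of 2-phenylethenyl for 2,3,4-trimethoxyphenyl gives a 1.8-fold lower number from compound 2 to compound 3 (0.24 log units; within the scatter) on a change from 8 to 12 heavy atoms and from 0 to 3 hydrogen-bond acceptors in the group. The comparison with the other aryl group, which exchanges 2-hydroxyphenyl for 2,3,4-trimethoxyphenyl, gives a 1.1-fold higher number from compound 1 to compound 3 (0.06 log units; within the scatter) and also stays within the scatter, so the two differently substituted aryl groups cannot be told apart on these numbers. Where the earlier compounds offered a single step, three groups at this position now give numbers that all lie within the scatter of one another, and no data shown here explain this.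

All three groups carry a six-membered aromatic ring of carbon only, so the compounds shown leave open whether a group without such a ring at this carbon, such as an amine, a carboxylic acid or a longer alkyl chain, would give a step beyond the scatter. They also leave open whether a single methoxy group on the phenyl ring would give a number that differs from these three.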